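A few compounds are considered here, and "the series" means these few. Any claim that something is new, unique, unknown or untested is made for them only; others in the source may bear on it.

Compound 1, `COc1ccc(S(=O)(=O)N2CCc3cccc(-c4ccc(O)cc4)c32)cc1`, in a functional assay on MKN-45 cells (Homo sapiens) for inhibition, with a stated time of 72 h; a lower number here means a stronger inhibitor, a higher number a weaker inhibitor: 82.6 nM
Compound 2, `COc1ccc(S(=O)(=O)N2CCc3cccc(-c4ccc(F)nc4)c32)cc1`, in this assay: 145 nM
Compound 3, `COc1ccc(S(=O)(=O)n2ccc3cccc(-c4ccc(F)cc4)c32)cc1`, in this assay: 170 nM

Among these three numbers compound 2 stands second highest. Its nearest neighbour is compound 3, whose number is within the scatter of that of compound 2, and its furthest is compound 1, which also lies within the scatter, so the three measured compounds cannot be told apart on these data.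

Compound 4, `COc1ccc(S(=O)(=O)N2CCc3cccc(-c4ccncc4)c32)cc1`, differs from compound 2 in one place: pyridin-4-yl in place of 6-fluoropyridin-3-yl on an aromatic carbon. Among the measured compounds shown here, the only measured step that bears on this place is the one from compound 1 to compound 2, where a different aromatic ring was exchanged at the same carbon and the result was a 1.8-fold higher number from compound 1 to compound 2 (0.24 log units; within the scatter). For the measured compounds named here, that step is the sole guide, and it was within the scatter; no measured pair tests a pyridin-4-yl against a 6-fluoropyridin-3-yl. The expectation is therefore that the step in this assay from compound 2 to compound 4 will not exceed the scatter in either direction.

On that basis compound 4 is estimated at 150 nM, with a range of 60 nM to 400 nM. This estimate corresponds to an expected step of a 1.0-fold higher number from compound 2 to compound 4 (0.01 log units; within the scatter).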

Compound 4, half-maximal inhibitory concentration: 69.5 nM
Compound 4: the middle estimate sits 2.2-fold (0.33 log units) above what was measured; the range from low to high includes it.
By their numbers in this assay, from the lowest: compounds 4, 1, 2 and 3 (each within the scatter of the next, the first and the last beyond it).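

In this assay, among the compounds shown here, pyridin-4-yl in place of 6-fluoropyridin-3-yl gives a 2.1-fold lower number from compound 2 to compound 4 (0.32 log units; beyond the scatter) and is the first step at this aromatic carbon to pass beyond the scatter, if only modestly, so the number at this position can respond to a change of ring. The step with pyridin-4-yl in place of 4-hydroxyphenyl gives a 1.2-fold lower number from compound 1 to compound 4 (0.07 log units; within the scatter) and stays within the scatter, so this pair cannot be told apart even though one group carries a ring nitrogen and the other a hydroxyl. Nothing available accounts for the difference between the 6-fluoropyridin-3-yl and pyridin-4-yl groups.

Compound 2 and compound 4 differ both in the fluorine and in the point of attachment of the ring, and the compounds shown do not separate these two changes, which a plain pyridin-3-yl group at the same carbon would begin to do. They also leave open how the number would respond to a group of another kind at this carbon, such as a morpholine or a carboxylic acid.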